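Replacing a methyl with a chloroacetamide on an aortic relaxation core

The compounds below may be only part of what the source reports. "The series", "measured", "known", "first", "only" and "open" are said of these compounds alone.

Measured so far:
compound 1 `Cc1ccc(CC2=NCCN2)cc1`: 5%
compound 2 `S=C=Nc1ccc(Cc2ncc[nH]2)cc1`: 68%

In an ADME assay on the whole organism (thoracic aorta) with Rattus norvegicus as the target (on this read-out higher numbers stand for larger maximal responses and lower numbers for smaller maximal responses), compound 1 gives 5%, the lower of the two numbers, while compound 2 gives 68%, beyond the scatter above it. Compound 3 `O=C(CCl)Nc1ccc(CC2=NCCN2)cc1` differs from compound 1 in one place: ((chloromethyl)carbonyl)amino in place of methyl on an aromatic carbon. For the measured compounds named here, with no measured pair showing this change, the expected step from compound 1 to compound 3 is uncertain but guessed upward, a number 35 percentage points higher from compound 1 to compound 3 (beyond the scatter). Compound 3 is expected to reach 40%, between 10% and 75%.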

Compound 3, largest response reached (Emax), in percent of the reference or control that the assay uses: 32%
The estimate for compound 3 lay 8 percentage points above the measured number; the range from low to high includes it.
By their numbers in this assay, from the lowest: compound 1; then compound 3; then compound 2.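

For the compounds shown here, this pair gives the first one-place comparison in the set. In this assay, placing ((chloromethyl)carbonyl)amino in place of methyl on the aromatic carbon of the shared core gives a number 27 percentage points higher from compound 1 to compound 3 (beyond the scatter), so the maximal response depends on what sits at this position. No available evidence says which part of the new group accounts for this step.

Going by these compounds, it remains open whether a plain amine, or an acetamide without the chlorine, would give a similar response at this carbon. Compound 2 differs from compound 1 and compound 3 in more than one place, so it cannot settle this question.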